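The source may hold more compounds than are shown below. What is called first, only, known or untested is meant among the compounds shown, and "the series" means these compounds.

In a functional assay on WiDr cells (Homo sapiens) for inhibition, read by sulforhodamine B assay, with a stated time of 48 h (a lower number here means a stronger inhibitor of growth, a higher number a weaker inhibitor of growth), compound 3 `O=C(CCCCc1ccccc1)OCC1COCCOCCOCCOCCOCCO1` gives > 100000 nM, which is a limit of the assay rather than a number. Compound 1 `O=C(CCCCOc1ccccc1)OCC1COCCOCCOCCOCCOCCO1` gives > 100000 nM in this assay, again only a limit. Compound 2 `CC/C=C/CC(=O)OCC1COCCOCCOCCOCCOCCO1` likewise gives > 100000 nM, a limit and not a number. Compound 3 therefore stands at the limit of > 100000 nM in this assay, at which 3 of the 3 values shown sit. The change from compound 3 to compound 4 `O=C(CCCCC1CCCCC1)OCC1COCCOCCOCCOCCOCCO1` is cyclohexyl in place of phenyl on a saturated chain carbon, four bonds along the chain from a carbonyl carbon. Within the data shown here, the measured step that touches the same place is a step that the two limits leave unreadable from compound 1 to compound 3, and the neighbouring steps a step that the two limits leave unreadable from compound 1 to compound 2 and a step that the two limits leave unreadable from compound 2 to compound 3 are equally unreadable, so no size of step in this assay can be drawn from them. Compound 4 is expected to remain at the limit, an estimated step of a number no higher from compound 3 to compound 4 (the limit leaves the size open). The estimated value of compound 4 is 100000 nM, between 30000 nM and 300000 nM.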

Compound 4, concentration for 50% growth inhibition: 33000 nM
Compound 4: middle estimate off by 3.0-fold (0.48 log units), on the high side; low and high end bracket the measured number.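

In this assay cyclohexyl in place of phenyl, on a saturated chain carbon four bonds along the chain from a carbonyl carbon, brings a readable number, with an at least 3.0-fold lower number from compound 3 to compound 4 (0.48 log units; beyond the scatter) at this place. Compound 4 also stands clear of the other two, with an at least 3.0-fold lower number from compound 2 to compound 4 (0.48 log units; beyond the scatter) and an at least 3.0-fold lower number from compound 1 to compound 4 (0.48 log units; beyond the scatter) in the same direction, whereas the steps among compound 1, compound 2 and compound 3 cannot be read. Of the compounds shown, only compound 4 leaves the limit: the limit of > 100000 nM in this assay, at which 3 of the 4 values shown sit.

As far as these compounds go, the true size of these steps stays open, as each rests on a limit. Also open, from the compounds shown here alone, is whether a longer chain carrying the cyclohexyl, or an amine in its place, would move the number further.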